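The source may hold more compounds than are shown below. What is called first, only, known or untested is meant among the compounds shown, and "the series" means these compounds.

Measured so far:
compound 1, `CC1(C)N=C(N)N=C(N)N1c1ccccc1S`: 6.86
compound 2, `CC1(C)N=C(N)N=C(N)N1c1ccccc1Cl`: 4.72

Compound 1 holds the highest of the two numbers recorded in an assay on isolated protein for inhibition of Dihydrofolate reductase (Mus musculus), at pH 7.20; a lower number here means a less potent compound, a higher number a more potent compound, by a factor of ten per unit of this negative logarithm. Its nearest neighbour is compound 2, and the drop is a number 2.14 log units lower from compound 1 to compound 2 (beyond the scatter), a large step for the exchange of a single heavy atom on an aromatic carbon of the shared core. Compound 3, `CC1(C)N=C(N)N=C(N)N1c1ccccc1O`, is still to be measured; it differs from compound 1 in the same place: hydroxy in place of sulfanyl on an aromatic carbon. Going by the values given here, only the step from compound 1 to compound 2 bears on this change, and it shows that replacing sulfanyl there can cost a great deal. Among the compounds with values here, no measured pair shows hydroxy at this position, so the size of the drop for compound 3 is uncertain. A step downward in this assay is expected, estimated as a number 1.26 log units lower from compound 1 to compound 3 (beyond the scatter), milder than the chloro case. Compound 3 is estimated to give 5.6, within 4.5 to 6.8.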

Compound 3, logarithm of the reciprocal of the active concentration, log(1/C): 2.92
Compound 3: the middle estimate sits 2.68 log units above what was measured; the measured number lies below the stated range.
By their numbers in this assay, from the lowest: compound 3; then compound 2; then compound 1.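

Exchanging one heavy atom here can cost far more than the chloro case suggested: in this assay, hydroxy in place of sulfanyl gives a number 3.94 log units lower from compound 1 to compound 3 (beyond the scatter), even though both groups count the same under hydrogen-bond donors, acceptors and charge. Hydroxy also falls short of chloro, with a number 1.80 log units lower from compound 2 to compound 3 (beyond the scatter), so the three groups at this place separate widely, and the two that match in those counts stand at opposite ends of the series. Nothing measured here accounts for this order.

The three compounds leave open whether compound 1 owes its standing to something particular to sulfanyl or whether other groups at this place could match it. An amine, a methyl group or a bromine atom on the same aromatic carbon would begin to settle that.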